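Relocating the Nitro Group: From Compound 1 to Compound 4

The source may report more compounds than this note shows. Statements on the series, on what has been measured and on what is new or still open speak of the compounds shown alone.

Measured compounds in a functional assay on SK-N-MC cells (Homo sapiens) for cytotoxicity, read by MTT assay; a lower number here means a stronger inhibitor, a higher number a weaker inhibitor:
compound 1 `COc1cc(/C=C2\CCC/C(=C\c3ccccc3[N+](=O)[O-])C2=O)cc(Br)c1OC` gives 6.24 ug/mL
compound 2 `CCCOc1c(Br)cc(/C=C2\CCC/C(=C\c3ccccc3[N+](=O)[O-])C2=O)cc1OC` gives 3.5 ug/mL
compound 3 `COc1cc(/C=C2\CCC/C(=C\c3ccc([N+](=O)[O-])cc3)C2=O)ccc1O` gives 48 ug/mL

Compound 1 stands second highest of these three numbers; compound 2 lies within the scatter of it, while compound 3 sits beyond the scatter at a higher number. Compound 4 `COc1cc(/C=C2\CCC/C(=C\c3ccc([N+](=O)[O-])cc3)C2=O)cc(Br)c1OC` differs from compound 1 by 4-nitrophenyl in place of 2-nitrophenyl on a double-bonded chain carbon bound to a double-bonded ring carbon. Among the measured compounds shown here, the only measured step, a 1.8-fold lower number from compound 1 to compound 2 (0.25 log units; within the scatter), concerns the alkoxy chain and does not bear on this change. Compound 3 also carries 4-nitrophenyl, but it differs from compound 1 at the other ring too, so its number gives only a loose hint. Compound 4 is therefore expected to give 12 ug/mL, with a range from 4 ug/mL to 40 ug/mL. The expected step is a 1.9-fold higher number from compound 1 to compound 4 (0.28 log units; within the scatter), carrying wide uncertainty.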

Compound 4, half-maximal inhibitory concentration: 9.86 ug/mL
For compound 4 the middle estimate is 1.2-fold (0.09 log units) above the measured one; measured number inside the range.
By their numbers in this assay, from the lowest: compounds 2, 1 and 4 (each within the scatter of the next, the first and the last beyond it); then compound 3.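

In this assay, 4-nitrophenyl in place of 2-nitrophenyl on a double-bonded chain carbon bound to a double-bonded ring carbon gives a 1.6-fold higher number from compound 1 to compound 4 (0.20 log units; within the scatter) and so stays within the scatter. Among the compounds shown here, this is the first direct reading of this change with the rest of compound 1 held fixed, and the two nitrophenyl groups cannot be told apart here. No measured evidence bears on why this is so.

On these data alone, whether the same holds with the propyl ether of compound 2 remains open. Also open, as far as these compounds go, is what an amine or a carboxylic acid would give in place of the nitro group.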